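Amide variation on a benzothiazole thioether: compound 4 expected

A few compounds are considered here, and "the series" means these few. Any claim that something is new, unique, unknown or untested is made for them only; others in the source may bear on it.

Compound 1, `COc1ccc(Br)cc1C(=O)Nc1ccc(Sc2nc3ccccc3s2)cc1`: > 100000 nM
Compound 2, `O=C(Nc1ccc(Sc2nc3ccccc3s2)c(Cl)c1)c1cccc(Br)c1`: > 100000 nM
Compound 3, `O=C(Nc1ccc(Sc2nc3ccccc3s2)c(Cl)c1)c1ccccc1`: > 100000 nM

Every result in an assay on isolated protein for inhibition of thiosulfate sulfurtransferase (Homo sapiens), with a stated time of 60 min, in the absence of a further agent (on this read-out lower numbers stand for stronger inhibition and higher numbers for weaker inhibition), sits at the limit of > 100000 nM in this assay, at which 3 of the 3 values shown sit, so each value is a limit of the assay and not a number. Compound 3 therefore stands at that limit, with > 100000 nM. Among the measured compounds shown here, the only step between measured neighbours, a step that the two limits leave unreadable from compound 2 to compound 3, has no readable size. Compound 4, `COc1ccc(Br)cc1C(=O)Nc1ccc(Sc2nc3ccccc3s2)c(Cl)c1`, differs from compound 3 by 5-bromo-2-methoxyphenyl in place of phenyl on a carbonyl carbon. For the measured compounds named here, no measured step covers this change, but compound 1 carries the same amide part and gives > 100000 nM, which is a limit. The expected step is therefore a step that the limit leaves unreadable from compound 3 to compound 4, no change beyond the scatter. Compound 4 is estimated at 200000 nM, between 30000 nM and 1000000 nM, most likely again only as a limit.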

Compound 4, half-maximal inhibitory concentration: > 100000 nM
Compound 4: only a limit was reported; the forecaster's own chance of this, stated with the estimate: 85%; the middle value lies beyond the limit too.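

In this assay compound 4 gives > 100000 nM as a limit, not a number. Its steps from compound 1, compound 2 and compound 3 therefore cannot be read: the limit of > 100000 nM in this assay, at which 4 of the 4 values shown sit. The compounds shown leave open which change to the shared core, if any, would give a readable value.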